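Anilino substitution in a thiophene ester ketone series

The source may hold more compounds than are shown below. What is called first, only, known or untested is meant among the compounds shown, and "the series" means these compounds.

Measured so far:
- compound 1 `COC(=O)c1c(Nc2ccccc2)sc(C(=O)c2ccc(OC)cc2)c1C`: 18%
- compound 2 `COC(=O)c1c(Nc2ccc(C)cc2)sc(C(=O)c2ccc(OC)cc2)c1C`: "not active" (no number reported)

For the measured compounds named here, in a functional assay, with a stated time of 150 min, tested at 10 ug/mL (on this read-out higher numbers stand for a stronger effect at the one concentration tested and lower numbers for a weaker effect), compound 1 gives 18%, the only number reported; compound 2 is recorded as "not active" (no number reported) without a number. Compound 3 `COC(=O)c1c(Nc2ccc(OC)cc2)sc(C(=O)c2ccc(OC)cc2)c1C` is not yet measured. It differs from compound 1 by methoxy in place of hydrogen on an aromatic carbon, anilino to (4-methoxyphenyl)amino. Going by the values given here, no step between measured compounds is available; the read-out of compound 2 suggests that substitution para to a large group does not raise the effect in this assay. A step of a number 8 percentage points lower from compound 1 to compound 3 (within the scatter) is expected, downward or none beyond the scatter. Compound 3 is estimated at 10%, range 0% to 25%.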

Compound 3, a percentage reported as activity, at one concentration (the size of the read-out at that concentration, not a potency): 5.9%
The estimate for compound 3 lay 4.1 percentage points above the measured number, within the range that was stated.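

Methoxy in place of hydrogen, para to a large group, gives the first step with a number at this position in this assay: a number 12.1 percentage points lower from compound 1 to compound 3 (beyond the scatter). For the compounds shown here, the effect of compound 3 remains a reported number, 5.9%, whereas compound 2 has no number, so no step links these two substituents. Nothing measured on these compounds bears on why the read-out falls with this change.

On these data alone, whether fluoro, an amine or a carboxylic acid at the same place also lowers the effect remains open. Also open, as far as these compounds go, is whether methoxy elsewhere on this ring gives a similar step.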